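Amino substitution on the carboxamide core of compound 3

This account rests on a few compounds, and the source may have more. Where it says the series, first, only, none or still open, it means among the compounds named here.

Compound 3 `NC(=O)c1cc2ccccc2s1` is the reference point of this series. In an assay on isolated protein for inhibition of LIM domain kinase 1 (Homo sapiens), read by Kinase-Glo, with a stated time of 60 min (on this read-out lower numbers stand for stronger inhibition and higher numbers for weaker inhibition), compound 3 gives only a limit of the assay, > 100000 nM. Two related compounds stand alongside it. Compound 1 `Nc1c(C(=O)O)sc2ncccc12` carries a carboxylic acid together with an amino group on a different fused core. In this assay compound 1 also reaches only a limit, > 100000 nM. Compound 2 `CCOC(=O)c1sc2ccccc2c1N` bears an ethyl ester together with an amino group on the same fused core as compound 3. In this assay compound 2 likewise sits at a limit, > 100000 nM. All three values coincide, as summarised by the limit of > 100000 nM in this assay, at which 3 of the 3 values shown sit. Among the compounds with values here, no step between measured compounds can be stated, since every value is a limit rather than a number.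

Compound 4 `NC(=O)c1sc2ccccc2c1N` is not yet measured. It differs from compound 3 by amino in place of hydrogen on an aromatic carbon. The same amino group is present in compound 1 and compound 2, both of which sit at a limit in this assay. No change beyond the scatter is expected in this assay, and a further limit is the most likely outcome. For compound 4 the expected value in this assay is 100000 nM, with a range from 30000 nM to 300000 nM. The step expected is a number no higher from compound 3 to compound 4 (the limit leaves the size open).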

Compound 4, half-maximal inhibitory concentration: 33000 nM
For compound 4 the middle estimate is 3.0-fold (0.48 log units) above the measured one, and the stated range covers the measured number.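

In this assay the series now holds its first number rather than a limit: amino in place of hydrogen, on the aromatic carbon next to the ring atom that bears a carbamoyl group, gives an at least 3.0-fold lower number from compound 3 to compound 4 (0.48 log units; beyond the scatter). The amino group is not enough by itself, as the change on the carbonyl carbon also counts: amino in place of ethoxy there gives an at least 3.0-fold lower number from compound 2 to compound 4 (0.48 log units; beyond the scatter). Even so, the number stands alone in the series, and the rest remains at the limit: the limit of > 100000 nM in this assay, at which 3 of the 4 values shown sit.

As far as these compounds go, the true size of both steps stays open, as each starts from a limit rather than a number. Also open, from the compounds shown here alone, is whether a methylamino group in place of the amino group, or a methyl group on the amide nitrogen, would hold or shift the number.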